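The compounds below may be only part of what the source reports. "The series", "measured", "known", "first", "only" and "open" are said of these compounds alone.

Measured so far:
- compound 1, `CCCCCOc1nc(N)c2nc(O)n(Cc3ccccc3)c2n1`: 0.3 mg/kg
- compound 2, `Nc1ncnc2c1nc(O)n2Cc1ccc(F)cc1`: 30 mg/kg

Going by the values given here, in a functional assay on the whole organism for activation, with Mus musculus as the target (on this read-out lower numbers stand for an effect already at smaller amounts and higher numbers for an effect only at larger amounts of compound), compound 1 gives 0.3 mg/kg, the lower of the two numbers known here. Compound 2 gives 30 mg/kg in this assay, a markedly higher number, well beyond the usual scatter; compound 2 differs from compound 1 at more than one place, so these two values only show how far apart the compounds lie.

The next compound is compound 3, `CSc1nc(N)c2nc(O)n(Cc3ccccc3)c2n1`. It differs from compound 1 in a single place: methylsulfanyl in place of pentyloxy on an aromatic carbon. The pentyloxy chain of compound 1 is thus replaced by the much shorter methylsulfanyl group, and only compound 1 offers a point of comparison for this position.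

Among the compounds with values here, since no measured pair shows the effect of such a change, the expectation is tentative. Compound 3 is expected to need a somewhat larger amount than compound 1, a step of a 3.3-fold higher number from compound 1 to compound 3 (0.52 log units; beyond the scatter) in this assay. For compound 3 the estimated value is 1 mg/kg, with a range from 0.2 mg/kg to 10 mg/kg.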

Compound 3, minimum effective dose: 0.1 mg/kg
Compound 3: middle estimate off by 10-fold (1.00 log units), on the high side; the measured number lies below the stated range.
By their numbers in this assay, from the lowest: compound 3; then compound 1; then compound 2.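

In this assay the swap of pentyloxy for methylsulfanyl gives a 3.0-fold lower number from compound 1 to compound 3 (0.48 log units; beyond the scatter). Going by these compounds alone, this is the first comparison at this aromatic carbon that changes one place only, and it shows that the effect at small doses does not depend on keeping the longer pentyloxy chain. No measurement shown here gives a reason for the step.

The chain length and the linking atom, oxygen or sulfur, change together in this step, so the two contributions cannot be told apart; a methoxy group or a pentylsulfanyl chain would separate them. On these data alone, it also remains open how this position responds to a group of a different kind, such as an amine, or to a chain of intermediate length, such as butyloxy.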